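Aryl Ether Variation on a Shared Acidic Core

The source may hold more compounds than are shown below. What is called first, only, known or untested is meant among the compounds shown, and "the series" means these compounds.

Compound 1 `O=C(O)c1csc([C@H]2CC[C@@H]3[C@@H](COc4cccc(F)c4)[C@H](O)C[C@@H]3O2)n1` was tested in an assay on HEK293 cells for agonist activity at prostaglandin E2 receptor EP2 subtype (Homo sapiens), read by a beta-galactosidase reporter and beta-arrestin recruitment, with a stated time of 90 min; a lower number here means that less compound is needed, a higher number that more compound is needed for the effect. There compound 1 gives > 10000 nM, which is a limit of the assay rather than a number. Compound 2 `O=C(O)c1csc([C@H]2CC[C@@H]3[C@@H](CCCOc4ccccc4)[C@H](O)C[C@@H]3O2)n1` gives > 10000 nM in this assay, and that too is only a limit. The step that the two limits leave unreadable from compound 1 to compound 2 therefore cannot be read, because of the limit of > 10000 nM in this assay, at which 2 of the 2 values shown sit. Compound 3 `O=C(O)c1csc([C@H]2CC[C@@H]3[C@@H](COc4ccccc4C(F)(F)F)[C@H](O)C[C@@H]3O2)n1` differs from compound 1 in one place: 2-(trifluoromethyl)phenyl in place of 3-fluorophenyl on an oxygen on a saturated carbon. For the measured compounds named here, no measured step gives a usable size for this change, since the single measured step sits between two limits. The two measured values show nothing that would move the read-out off the limit when the aryl ether is varied, so compound 3 is expected to remain close to it. Compound 3 is estimated at 10000 nM, between 2000 nM and 50000 nM. The step of a number no higher from compound 1 to compound 3 (the limit leaves the size open) is accordingly expected to lie within the scatter.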

Compound 3, half-maximal effective concentration: 11 nM
The estimate for compound 3 lay 910-fold (2.96 log units) above the measured number; measured number below the stated range.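

In this assay, the aryl group on this oxygen proves able to move the read-out by a large amount: 2-(trifluoromethyl)phenyl in place of 3-fluorophenyl gives an at least 900-fold lower number from compound 1 to compound 3 (2.95 log units; beyond the scatter). The earlier pair could not show this, and the step between compound 1 and compound 2 cannot be read: the limit of > 10000 nM in this assay, at which 2 of the 3 values shown sit. Compound 3 is the only one of the three with a number rather than a limit, so its step gives only the least size of the change.

The compounds shown leave open whether a methyl or a chlorine could stand in for the trifluoromethyl group on this aryl ring. For the compounds shown here, they also leave open whether 2-(trifluoromethyl)phenyl would keep its effect on a longer chain, such as the one in compound 2.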